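Swapping methoxy for bromo on a four-carbon linker

The source may report more compounds than this note shows. Statements on the series, on what has been measured and on what is new or still open speak of the compounds shown alone.

Four compounds share a dithiolane-bearing amide joined through a triazole and a short chain to a coumarin-like core. In a functional assay on PC-12 cells (Rattus norvegicus) for cytotoxicity, read by MTT assay, with stated times of 3 h and 2 h, tested at 20 uM (on this read-out lower numbers stand for a weaker effect and higher numbers for a stronger effect at the one concentration tested), compound 1 `COc1ccc(-c2cc3ccc(OCCCn4cc(CNC(=O)CCCCC5CCSS5)nn4)cc3oc2=O)cc1` gives 62%, compound 2 `O=C(CCCCC1CCSS1)NCc1cn(CCCOc2ccc3cc(-c4ccc(Br)cc4)c(=O)oc3c2)nn1` gives 69.1%, and compound 3 `COc1ccc(-c2cc3ccc(OCCCCn4cc(CNC(=O)CCCCC5CCSS5)nn4)cc3oc2=O)cc1` gives 52.3%. Compound 4 `O=C(CCCCC1CCSS1)NCc1cn(CCCCOc2ccc3cc(-c4ccc(Br)cc4)c(=O)oc3c2)nn1` has not been measured in this assay.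

Compound 1 and compound 2 differ in one place: bromo in place of methoxy on an aromatic carbon. That change made a step of a number 7.1 percentage points higher from compound 1 to compound 2 (within the scatter), a step that lies within the scatter of this kind of measurement, so the two values cannot be ordered with confidence.

Compound 3 and compound 4 differ in exactly the same place: bromo in place of methoxy on an aromatic carbon. The place lines of the two changes agree word for word, so this is the same change made on a second core. How the core of compound 3 differs from the core of compound 1 is not broken down here; the two cores differ in more than one place.

Among the measured compounds shown here, compound 3 stands lowest of the three numbers so far, although its gap to compound 1 is within the scatter. Because the earlier step of a number 7.1 percentage points higher from compound 1 to compound 2 (within the scatter) was small, compound 4 is expected to move only a little from compound 3, with an expected step of a number 6.7 percentage points higher from compound 3 to compound 4 (within the scatter) in this assay. Compound 4 is estimated at 59%, expected to fall between 46% and 72%.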

Compound 4, a percentage reported as activity, at one concentration (the size of the read-out at that concentration, not a potency): 45%
The estimate for compound 4 lay 14 percentage points above the measured number; the whole stated range lies above it.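

On the second core, the swap from 4-methoxyphenyl to 4-bromophenyl gave, in this assay, a number 7.3 percentage points lower from compound 3 to compound 4 (within the scatter). Neither step alone can be told from ordinary repeat-to-repeat variation, yet set side by side they differ by more than that variation allows, so the change did not shift the read-out by the same amount on the two cores: the same change on two cores in this assay, a number 7.1 percentage points higher (within the scatter) from compound 1 to compound 2 and a number 7.3 percentage points lower (within the scatter) from compound 3 to compound 4, 14.4 percentage points apart, beyond the scatter of two such steps. This does not show that bromo truly raises the number on one core and lowers it on the other, since each step taken alone remains within the scatter, and two pairs of compounds at a single concentration cannot say which part of the cores is tied to the mismatch or why it arises.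

The compounds shown leave open how other groups on the same aromatic carbon, such as chloro, a nitrile or an amine, would read on these two cores, and whether they too would give steps that do not match from one core to the other. They also leave open what a longer chain in the linker would do, and whether the mismatch between the two steps would hold at other concentrations.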